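Swapping one aromatic arm: a lipophilicity outlook

The compounds below may be only part of what the source reports. "The series", "measured", "known", "first", "only" and "open" are said of these compounds alone.

Of the compounds shown here, two have been measured in a physicochemical assay for lipophilicity, read by HPLC, at pH 7.5; on this read-out lower numbers stand for lower lipophilicity and higher numbers for higher lipophilicity. Compound 1 `CC[C@@H](Nc1c(C#N)c(-c2ccc(-c3ncccc3C)cc2)nc2cnccc12)C(N)=O` gives 2 in this assay, and compound 2 `CC(Nc1c(C#N)c(-c2ccc(Br)cc2)nc2cnccc12)C(N)=O` gives 2.1. Compound 1 holds the lower of the two numbers, but the gap to compound 2 lies within the scatter, so the two readings cannot be told apart.

Compound 3 `CC[C@@H](Nc1c(C#N)c(-c2ccc(-c3ccccc3NC)cc2)nc2cnccc12)C(N)=O` has not been measured. It differs from compound 1 in one place: 2-(methylamino)phenyl in place of 3-methylpyridin-2-yl on an aromatic carbon. The group that leaves and the group that enters sit on the same aromatic carbon, para to a large group.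

Within the data shown here, no step between two measured compounds matches this change, so the expectation rests on the change itself. A modest rise beyond the scatter is expected, with a step of a number 0.50 log units higher from compound 1 to compound 3 (beyond the scatter). Compound 3 is therefore estimated at 2.5, within a range from 2 to 3.1.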

Compound 3, distribution coefficient: 2.5
For compound 3 middle estimate and measured number coincide at the digits printed; low and high end bracket the measured number.
By their numbers in this assay, from the lowest: compounds 1 and 2 (each within the scatter of the next); then compound 3.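

In this assay, among these compounds, replacing 3-methylpyridin-2-yl with 2-(methylamino)phenyl on an aromatic carbon, para to a large group, gives the first readable step, a number 0.50 log units higher from compound 1 to compound 3 (beyond the scatter), so a change of arm at this position can move the number beyond the scatter. Several differences arrive together in this one swap: the entering group has a ring of carbon only, one hydrogen-bond donor and one more heavy atom, while the leaving group has a ring with one hetero atom and no donor. Nothing available here links the step to any one of these differences.

On these data alone, it remains open whether the ring change or the donor goes with the step; a plain phenyl, or a phenyl carrying a dimethylamino group or a carboxylic acid, could help to separate them. As far as these compounds go, whether the same swap gives a similar step on a different core also remains open.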